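The compounds below may be only part of what the source reports. "The series", "measured", "known", "first", "only" and "open" are said of these compounds alone.

Compound 2 `CNC(=O)c1cc(Oc2ccc(NC(=O)c3cc(-c4ccc(F)cc4)ncn3)cc2F)ccn1` is the starting point of this step. In a functional assay on PC-3 cells (Homo sapiens) for cytotoxicity, read by MTT assay, with a stated time of 72 h (a lower number here means a stronger inhibitor, a higher number a weaker inhibitor), compound 2 gives > 100000 nM, which is a limit of the assay and not a number. Among the measured compounds shown here, it is the one value among the three that sits at the limit of > 100000 nM in this assay, at which 1 of the 3 values shown sits. Compound 3 `CNC(=O)c1cc(Oc2ccc(NC(=O)c3cc(-c4ccc(OC)cc4)ncn3)cc2F)ccn1`, with methoxy in place of fluoro on an aromatic carbon, gives 56200 nM in this assay, a change of an at least 1.7-fold lower number from compound 2 to compound 3 (0.25 log units; that floor lies within the scatter). Compound 1 `CNC(=O)c1cc(Oc2ccc(NC(=O)c3nccc(-c4ccc(OC)cc4)n3)cc2)ccn1` differs from compound 3 by having hydrogen in place of fluoro on an aromatic carbon; in this assay compound 1 gives 14200 nM.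

Compound 4 `CNC(=O)c1cc(Oc2ccc(NC(=O)c3cc(-c4ccc(F)cc4)ncn3)cc2)ccn1` is not yet measured. It differs from compound 2 by hydrogen in place of fluoro on an aromatic carbon. For the measured compounds named here, the only measured step, from compound 2 to compound 3, concerns a different change and gives only a floor within the scatter. Going by the values given here, the pair of compound 1 and compound 3 shows what the same fluoro removal did on the methoxy analogue, but no step is given for that pair, and compound 2 itself is a limit. For compound 4 the expected value in this assay is 60000 nM, with a range from 20000 nM to 200000 nM, the expected step from compound 2 being an at least 1.6-fold lower number from compound 2 to compound 4 (0.22 log units; that floor lies within the scatter).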

Compound 4, half-maximal inhibitory concentration: > 100000 nM
Compound 4: no number, only a limit (the forecaster's own chance of this, stated with the estimate: 35%); middle value at least 1.6-fold (0.22 log units) from the limit.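

No step can be read from compound 2 to compound 4, because both compounds stand at a limit of the assay and not at a number: the limit of > 100000 nM in this assay, at which 2 of the 4 values shown sit.

Still open, going by these compounds, is whether hydrogen in place of fluoro on an aromatic carbon changes the result for this pair in this assay at all.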